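The compounds below may be only part of what the source reports. "The series", "measured", "known", "first", "only" and "open" are said of these compounds alone.

Measured compounds in an assay on CHO cells for antagonist activity at transient receptor potential cation channel subfamily V member 1 (Homo sapiens), read by FLIPR; a higher number here means a weaker inhibitor, a lower number a stronger inhibitor:
- compound 1 `CC(C(=O)NCc1ccc(C(F)(F)Cl)nc1N1CCCCC1)c1ccc(NS(C)(=O)=O)c(F)c1` gives 1.3 nM
- compound 2 `Cc1cc(C(F)(F)F)nc(N2CCC(C)CC2)c1CNC(=O)C(C)c1ccc(NS(C)(=O)=O)c(F)c1` gives 17.5 nM
- compound 3 `CCCCCCOc1nc(C(F)(F)F)cc(C)c1CNC(=O)C(C)c1ccc(NS(C)(=O)=O)c(F)c1` gives 100 nM

Compound 3 carries the highest number of the three in this assay. For the measured compounds named here, its nearest neighbour is compound 2, and the single step between them, a 5.7-fold higher number from compound 2 to compound 3 (0.76 log units; beyond the scatter), lies beyond the scatter; compound 1 stands furthest from it, with a gap that is also beyond the scatter, though no single-point step links those two.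

Compound 4 `Cc1cc(C(F)(F)F)nc(OC2CCCC2)c1CNC(=O)C(C)c1ccc(NS(C)(=O)=O)c(F)c1` is not yet measured. It differs from compound 3 by cyclopentyl in place of hexyl on an oxygen on an aromatic ring. Going by the values given here, no measured step bears on this change: the only step, from compound 2 to compound 3, swaps a ring amine for a chain ether, not one alkoxy group for another. What the numbers show is that the hexyloxy member sits at the weak end of the series, and that the replacement keeps an alkoxy group while shortening the chain and closing it into a ring. With nothing to anchor the direction, the step is expected to stay close to compound 3, with a slight lean towards a lower number: an expected step of a 1.7-fold lower number from compound 3 to compound 4 (0.22 log units; within the scatter).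

Compound 4 is therefore estimated at 60 nM in this assay, within a range of 20 nM to 200 nM.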

Compound 4, inhibition constant: 44 nM
Compound 4: the middle estimate sits 1.4-fold (0.13 log units) above what was measured; low and high end bracket the measured number.
By their numbers in this assay, from the lowest: compound 1; then compound 2; then compound 4; then compound 3.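

In this assay, the result shows that this position responds to the group on the oxygen and not only to the choice of ether over ring amine: cyclopentyl in place of hexyl gives a 2.3-fold lower number from compound 3 to compound 4 (0.36 log units; beyond the scatter), a modest change beyond the scatter. Cyclopentyloxy in place of 4-methylpiperidin-1-yl still gives a 2.5-fold higher number from compound 2 to compound 4 (0.40 log units; beyond the scatter), so part of the loss seen in a 5.7-fold higher number from compound 2 to compound 3 (0.76 log units; beyond the scatter) is recovered, while both ethers remain on the weaker side of the ring amine of compound 2. The change removes a carbon and closes a ring in one move, so the two contributions cannot be separated here, and no measurement on hand explains the step.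

A butyl or pentyl chain on the same oxygen, or a cyclohexyl ring there, would help to show whether the ring or the shorter carbon count goes with the lower number. Going by these compounds, it also remains open whether the ordering of cyclopentyloxy and 4-methylpiperidin-1-yl holds on the core of compound 1, or whether a small methoxy group or a secondary amine at this place would fall in the same range.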